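The source may hold more compounds than are shown below. What is called first, only, known or untested is meant among the compounds shown, and "the series" means these compounds.

This small series is built on a shared spiro core and tested in a functional assay on A549 cells (Homo sapiens) for antiproliferative activity, read by MTT assay, with a stated time of 48 h; a higher number here means a weaker inhibitor, a lower number a stronger inhibitor. Compound 1 `N#CC1=C(N)Oc2c(c3nc4ccccc4nc3c3ccccc23)C12C(=O)N(Cc1cnnn1-c1cc(Cl)ccc1Cl)c1ccccc12` gives in this assay a value of > 50000 nM, which is a limit of the assay and not a measured number. Compound 2 `N#CC1=C(N)Oc2c(N)cc3nc4ccccc4nc3c2C12C(=O)N(Cc1cnnn1-c1ccc(F)cc1)c1ccccc12` gives in this assay > 50000 nM, again a limit rather than a number. So compound 2 stands exactly where the only other compound stands: both results sit at the limit of > 50000 nM in this assay, at which 2 of the 2 values shown sit, and no compound has yet produced a measurable inhibition.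

Compound 3 `Cc1ccc(Cl)cc1-n1nncc1CN1C(=O)C2(C(C#N)=C(N)Oc3c(N)cc4nc5ccccc5nc4c32)c2ccccc21` differs from compound 2 in one place, (5-chloro-2-methylphenyl in place of 4-fluorophenyl on an aromatic nitrogen). Among the compounds with values here, no step between two measured compounds exists here, so there is no measured guide to how large an effect this kind of change produces. Since the starting point is itself only a limit, the expectation is for no step beyond the scatter, and the most likely outcome for compound 3 is that this assay again reports only a limit. Compound 3 is therefore expected to show 60000 nM, in a range from 20000 nM to 200000 nM, meaning an estimated step that the limit leaves unreadable from compound 2 to compound 3 that amounts to essentially no change.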

Compound 3, half-maximal inhibitory concentration: > 50000 nM
Compound 3 ended at the assay's limit (the forecaster's own chance of this, stated with the estimate: 85%); the middle value does not contradict the limit.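

Going by these compounds, compound 2 and compound 3 both stop at a limit of this assay rather than at a number, so no step can be read between them, and the effect of 5-chloro-2-methylphenyl in place of 4-fluorophenyl stays unknown. The compounds shown leave open whether any compound on this shared core gives a measurable value in this assay.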